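A few compounds are considered here, and "the series" means these few. Any claim that something is new, unique, unknown or untested is made for them only; others in the source may bear on it.

Measured so far:
compound 1 `O=C(/N=C1\NC2(CCCCO2)CCS1)c1ccc(Br)cc1`: > 200 mg/kg
compound 2 `O=C(/N=C1\NC2(CCCCO2)CCS1)c1ccccc1Cl`: > 200 mg/kg

In a functional assay on the whole organism (strain CF-1) with Mus musculus as the target, in the writhing test, with a stated time of 15 min (a lower number here means that less compound is needed, a higher number that more compound is needed for the effect), compound 1 gives > 200 mg/kg, a limit of the assay and not a number. Compound 2 gives > 200 mg/kg, again only a limit. The step that the two limits leave unreadable from compound 1 to compound 2 is therefore unreadable in size and direction. Compound 2 stands at the limit of > 200 mg/kg in this assay, at which 2 of the 2 values shown sit; no number marks its place within the series.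

Compound 3 `O=C(/N=C1\NC2(CCCCO2)CCS1)c1ccccc1O` differs from compound 2 by hydroxy in place of chloro on an aromatic carbon. Within the data shown here, the only measured step, a step that the two limits leave unreadable from compound 1 to compound 2, runs between two limits and gives no reading that bears on this change, so no size of step can be drawn from the series. The step that the limit leaves unreadable from compound 2 to compound 3 is therefore expected to stay at or near the limit, with no direction that can be read from the data. Compound 3 is expected to give 300 mg/kg, within 120 mg/kg to 800 mg/kg, most likely again as a limit.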

Compound 3, dose for half-maximal effect: > 200 mg/kg
Compound 3: a limit, no number (the forecaster's own chance of this, stated with the estimate: 70%); the middle value is on the limit's open side.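

In this assay compound 3 gives > 200 mg/kg, a limit and not a number. Among these compounds, no step among compound 1, compound 2 and compound 3 can be read, in size or in direction: the limit of > 200 mg/kg in this assay, at which 3 of the 3 values shown sit. The compounds shown leave open how these three compare and what dose any of them needs for the effect.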